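Benzyl to 3-chloro-4-fluorobenzyl on compound 2

This account rests on a few compounds, and the source may have more. Where it says the series, first, only, none or still open, it means among the compounds named here.

In an ADME assay on microsomes from liver (Homo sapiens) for metabolic stability, with a stated time of 60 min, tested at 1 uM (on this read-out higher numbers stand for a more stable compound and lower numbers for a less stable compound), compound 2 `CS(=O)(=O)Nc1ccc2c(c1)S(=O)(=O)N=C(C1=C(O)[C@@H]3[C@@H]4CC[C@@H](C4)[C@@H]3N(Cc3ccccc3)C1=O)N2` gives 90% and compound 1 `CS(=O)(=O)Nc1ccc2c(c1)S(=O)(=O)N=C(C1=C(O)[C@@H]3[C@H]4CC[C@H](C4)[C@@H]3N(Cc3ccccc3)C1=O)N2` gives 80% so the two stand within the scatter of each other. Compound 3 `CS(=O)(=O)Nc1ccc2c(c1)S(=O)(=O)N=C(C1=C(O)[C@@H]3[C@@H]4CC[C@@H](C4)[C@@H]3N(Cc3ccc(F)c(Cl)c3)C1=O)N2` differs from compound 2 in one place: 3-chloro-4-fluorophenyl in place of phenyl on a saturated chain carbon bound to an amide-type nitrogen in a ring reads, one bond further out, as benzyl to 3-chloro-4-fluorobenzyl. For the measured compounds named here, the only measured step of a number 10 percentage points higher from compound 1 to compound 2 (within the scatter) alters configuration alone (the fact that compounds 1 and 2 differ only in the configuration as drawn) and leaves the benzyl untouched, so it offers no guide here and no step beyond the scatter is expected in this assay for this change. The expected step of a number 5 percentage points lower from compound 2 to compound 3 (within the scatter) thus stays within the scatter. For compound 3 the estimate is 85% with an expected range from 65% to 97% on this read-out.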

Compound 3, percent of the compound remaining: 100%
Compound 3: the middle estimate sits 15 percentage points below what was measured; measured number above the stated range.
By their numbers in this assay, from the lowest: compounds 1, 2 and 3 (each within the scatter of the next, the first and the last beyond it).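

For the compounds shown here, compounds 1 and 2 carry the same benzyl, so compound 3 gives the only view of a change to the group itself. With 3-chloro-4-fluorophenyl in place of phenyl on a saturated chain carbon bound to an amide-type nitrogen in a ring, this assay shows a number 10 percentage points higher from compound 2 to compound 3 (within the scatter), so this position takes both halogens without a step beyond the scatter. Nothing at hand bears on a cause for this step.

Open remain whether chlorine or fluorine alone would read the same, and how an amine, a carboxylic acid or a longer chain at this position would fare in this assay.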